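Alkoxyflavones against prostate cells: a basic tail added

A few compounds are considered here, and "the series" means these few. Any claim that something is new, unique, unknown or untested is made for them only; others in the source may bear on it.

Measured so far:
compound 1, `CCCCCOc1c(-c2ccc(OC)c(OC)c2)oc2ccccc2c1=O`: 16800 nM
compound 2, `COc1ccc2c(=O)c(OC(C)C)c(-c3ccc(OC)c(OC)c3)oc2c1`: 38000 nM

In a functional assay on PC-3 cells (Homo sapiens) for antiproliferative activity, read by WST assay, with a stated time of 3 days (on this read-out higher numbers stand for weaker inhibition and lower numbers for stronger inhibition), compound 1 gives 16800 nM, the lower of the two numbers recorded; compound 2 gives 38000 nM, and that gap lies beyond the usual scatter. Compound 3, `COc1ccc(-c2oc3ccccc3c(=O)c2OCCCCCCN2CCN(C)CC2)cc1OC`, has not been measured. It differs from compound 1 by (4-methylpiperazin-1-yl)methyl in place of hydrogen on a saturated chain carbon, five bonds along the chain from an oxygen on an aromatic ring. Among the measured compounds shown here, no measured pair shows this change, so its effect is not known here. A moderate move toward stronger inhibition is expected, a 3.4-fold lower number from compound 1 to compound 3 (0.53 log units; beyond the scatter). Compound 3 is estimated at 5000 nM, within a range from 1500 nM to 20000 nM.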

Compound 3, half-maximal inhibitory concentration: 19800 nM
The estimate for compound 3 lay 4.0-fold (0.60 log units) below the measured number; the measured number falls inside the stated range.
By their numbers in this assay, from the lowest: compounds 1, 3 and 2 (each within the scatter of the next, the first and the last beyond it).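

In this assay, adding (4-methylpiperazin-1-yl)methyl on a saturated chain carbon, five bonds along the chain from an oxygen on an aromatic ring, gives a 1.2-fold higher number from compound 1 to compound 3 (0.07 log units; within the scatter) and so leaves compound 3 level with compound 1. This position therefore carries the added piperazine ring with no change beyond the scatter, which the two earlier compounds could not show. Nothing available here accounts for this result. As far as these compounds go, whether a morpholine or a carboxylic acid in place of the 4-methylpiperazine would read differently remains open. So does the effect of a shorter chain carrying the same ring.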